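Compound 1 to compound 4: methyl replacing difluoromethyl

A few compounds are considered here, and "the series" means these few. Any claim that something is new, unique, unknown or untested is made for them only; others in the source may bear on it.

Measured in an ADME assay on microsomes from liver (Rattus norvegicus) for metabolic stability (on this read-out higher numbers stand for a longer-lived compound and lower numbers for a shorter-lived compound), so far:
compound 1 `C[C@@H](c1ccc(OC(F)F)cc1)N1CC[C@](CCC(N)=O)(c2ccc(F)cc2)OC1=O` gives > 1 h (a limit)
compound 2 `Cc1cc(-c2ccc([C@H](C)N3CC[C@](CC(C)(C)O)(c4ccccc4)OC3=O)cc2)cc(C)n1` gives > 0.75 h (a limit)
compound 3 `Cc1cc(-c2ccc([C@H](C)N3CC[C@](CCCO)(c4ccccc4)OC3=O)cc2)cc(C)n1` gives 0.217 h

Compound 1 stands at > 1 h as a limit and not a number. Only compound 3 has a true number among the three readings.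

Compound 4 `COc1ccc([C@H](C)N2CC[C@](CCC(N)=O)(c3ccc(F)cc3)OC2=O)cc1` differs from compound 1 in one place, (methyl in place of difluoromethyl on an oxygen on an aromatic ring), with methyl in place of difluoromethyl on an oxygen on an aromatic ring. Within the data shown here, no measured step touches this group. Among the measured compounds shown here, the only measured step is an at least 3.4-fold lower number from compound 2 to compound 3 (0.53 log units; beyond the scatter), with 2-hydroxyethyl in place of 1-hydroxy-1-methylethyl elsewhere in the molecule. It shows that a single change can move this assay beyond the scatter, but it gives no size for the present change. The expected step, a judgement with wide uncertainty, is an at least 1.6-fold lower number from compound 1 to compound 4 (0.22 log units; that floor lies within the scatter), towards a shorter-lived compound. A reading that is again only a limit is also expected to remain possible. For compound 4 the estimated half-life is 0.6 h, with an expected range from 0.2 h to 1.5 h for the measurement.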

Compound 4, half-life: 0.15 h
Compound 4: middle estimate off by 4.0-fold (0.60 log units), on the high side, and the stated range ends above it.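

In this assay, among these compounds, methyl in place of difluoromethyl on an oxygen on an aromatic ring gives an at least 6.6-fold lower number from compound 1 to compound 4 (0.82 log units; beyond the scatter), so this one position can move the half-life beyond the scatter, which no earlier step had tested. The true size of the step stays unknown, and the figure is only a floor, because compound 1 is held at a limit: the limit of > 1 h in this assay, at which 1 of the 4 values shown sits.
Compound 4 gives 0.15 h, a true number, so further changes on this oxygen can be read against it.

Open, on these data alone, is whether the step follows the fluorine atoms or the whole group on the oxygen; trifluoromethyl, monofluoromethyl or ethyl there would separate these. Also open, as far as these compounds go, is whether the same change carries over to compounds with the side chains of compound 2 and compound 3.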